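This account rests on a few compounds, and the source may have more. Where it says the series, first, only, none or still open, it means among the compounds named here.

Compound 1, `CC(C)C[C@H](N)c1ccccc1N1CCN(C(=O)[C@H](C)Cc2ccc(Cl)cc2F)CC1`, gives 67 nM in an assay on HEK293 cells for displacement of a labelled ligand from Melanocortin receptor 4 (Homo sapiens); on this read-out lower numbers stand for stronger inhibition and higher numbers for weaker inhibition.
Compound 2, `CC(C)C[C@H](N)c1cc(Cl)ccc1N1CCN(C(=O)C(C)Cc2ccc(Cl)cc2)CC1`, gives 67 nM in this assay.
Compound 3, `CC(C)C[C@H](N)c1cc(F)ccc1N1CCN(C(=O)C(C)Cc2ccc(Cl)cc2)CC1`, gives 390 nM in this assay.

Of the compounds shown here, three around a shared core have been measured. Compound 1 and compound 2 stand level at the digits printed, and compound 3 lies furthest from them. Going by the values given here, the one step that can be counted is chloro in place of fluoro on an aromatic carbon, which gave a 5.8-fold lower number from compound 3 to compound 2 (0.76 log units; beyond the scatter). The difference between the core of compound 1 and the core of compound 3 is not broken down here.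

Compound 4, `CC(C)C[C@H](N)c1ccccc1N1CCN(C(=O)[C@H](C)Cc2ccc(Cl)cc2Cl)CC1`, is not yet measured. It differs from compound 1 by chloro in place of fluoro on an aromatic carbon. Among the compounds with values here, this is the same kind of change as the one from compound 3 to compound 2, but not the same: there it sat meta to a 1-amino-3-methylbutyl group and para to a large group, whereas here it sits ortho to a large group and meta to a chloro group, on the other ring. Resting on the earlier step alone, compound 4 is expected to show a 1.7-fold lower number from compound 1 to compound 4 (0.22 log units; within the scatter), a smaller move than the earlier one since the surroundings differ. Compound 4 is therefore estimated at 40 nM, between 15 nM and 120 nM.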

Compound 4, inhibition constant: 16 nM
The estimate for compound 4 lay 2.5-fold (0.40 log units) above the measured number, and the stated range covers the measured number.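

In this assay the change from 4-chloro-2-fluorobenzyl to 2,4-dichlorobenzyl gave a 4.2-fold lower number from compound 1 to compound 4 (0.62 log units; beyond the scatter) and so lowered the number on a second core as well, with the chloro now on the other ring. The two steps point the same way and do not differ in size beyond what repeated measurements would allow: the same change on two cores in this assay, a 5.8-fold lower number (0.76 log units; beyond the scatter) from compound 3 to compound 2 and a 4.2-fold lower number (0.62 log units; beyond the scatter) from compound 1 to compound 4, 1.4-fold (0.14 log units) apart, within the scatter of two such steps. This shows that, across these two pairs, chloro in place of fluoro on an aromatic carbon carried over from one core to the other, but two pairs cannot show that it would hold at every place or on every core in the series, and they give no explanation for the effect.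

The compounds shown leave open whether a bromo, a methyl or a methoxy group at the same place would lower the number further. They also leave open whether the step survives when the 1-amino-3-methylbutyl group gives way to a longer chain or a cyclic amine.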